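Mirror-Image Partner of Compound 2 at the Alpha4/Beta2 Receptor

The source may report more compounds than this note shows. Statements on the series, on what has been measured and on what is new or still open speak of the compounds shown alone.

Of the compounds shown here, two have been tested in a functional assay on HEK293 cells for agonist activity at Neuronal acetylcholine receptor; alpha4/beta2 (Homo sapiens), read by FLIPR; on this read-out lower numbers stand for an effect already at smaller amounts and higher numbers for an effect only at larger amounts of compound. Compound 1, `Clc1cc(N2CC[C@@H]3CN[C@@H]3C2)cnc1Cl`, gives 82 nM in this assay. Compound 2, `c1cncc(N2C[C@@H]3CCNC[C@@H]32)c1`, gives 410 nM in this assay, the highest of the two numbers; compound 1 has the lower number, and the gap between them is beyond the usual scatter. Compound 3, `c1cncc(N2C[C@H]3CCNC[C@H]32)c1`, is the not yet measured partner of compound 2. The difference between them is the two compounds have the same atoms and bonds and differ only in configuration as drawn: 2 of 2 stereo elements differ (all stereocentres are inverted: mirror images); a stereocentre at a saturated ring carbon is drawn S in compound 2 and R in compound 3; a stereocentre at a saturated ring carbon is drawn R in compound 2 and S in compound 3: the two compounds have the same atoms and bonds and differ only in configuration as drawn, all stereocentres being inverted, so compound 3 is the mirror image of compound 2. Among the compounds with values here, no measured pair in this set shows what inverting both stereocentres does in this assay, so the direction of the step cannot be read from the data. Mirror images can give numbers far apart or close together in this assay. Compound 3 is therefore expected at 300 nM, within a wide range from 40 nM to 3000 nM, and the expected step of a 1.4-fold lower number from compound 2 to compound 3 (0.14 log units; within the scatter) is near zero with large uncertainty on either side.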

Compound 3, half-maximal effective concentration: 1400 nM
The estimate for compound 3 lay 4.7-fold (0.67 log units) below the measured number; measured number inside the range.
By their numbers in this assay, from the lowest: compound 1; then compound 2; then compound 3.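

Inverting both stereocentres gives a 3.4-fold higher number from compound 2 to compound 3 (0.53 log units; beyond the scatter) in this assay. Within the data shown here, this is the first pair here in which configuration is the only variable, and it shows that this assay can tell these two mirror images apart, with the arrangement drawn in compound 2 giving an effect at smaller amounts than the arrangement drawn in compound 3. The gap can be assigned to configuration alone, and not to any added or removed group, because nothing else separates the pair: the fact that compounds 2 and 3 differ only in the configuration as drawn

Compound 1 differs from compound 2 and compound 3 in more than one place, so the compounds shown cannot say how much of its lower number comes from its chlorine atoms and how much from its core. Going by these compounds, it also remains open whether the same preference between mirror images would hold in other members, such as the mirror image of compound 1 or a mirror-image pair carrying a methoxy group or a nitrile on the shared core.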